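Amidine series: swapping fluoro for methoxy and hemolysis

The compounds below may be only part of what the source reports. "The series", "measured", "known", "first", "only" and "open" are said of these compounds alone.

Measured so far:
compound 1 `N=C(N)c1ccc(-c2ccc(-c3ccc(F)cc3)o2)o1`: 66.3%
compound 2 `N=C(N)c1ccc(-c2ccc(-c3ccccc3)s2)s1`: 56.7%
compound 3 `N=C(N)c1ccc(-c2ccc(-c3ccc4ccccc4c3)s2)s1`: 13%

In an ADME assay on cells (Erythrocyte, Homo sapiens) for activation, read by hemolysis, with a stated time of 30 min, tested at 5 mM (a higher number here means a stronger effect of the compound at the concentration tested, a lower number a weaker effect), compound 1 gives 66.3%, the highest of the three numbers. Compound 2 gives 56.7%, a gap within the scatter, so the two cannot be ordered. Compound 3, with 13%, sits well beyond the scatter below compound 1. Compound 4 `COc1ccc(-c2ccc(-c3ccc(C(=N)N)o3)o2)cc1` has not been measured in this assay. It differs from compound 1 as follows: methoxy in place of fluoro on an aromatic carbon. Among the measured compounds shown here, no measured pair isolates this change, so compound 4 is expected to stay roughly where compound 1 stands, with an estimated step of a number 11.3 percentage points lower from compound 1 to compound 4 (beyond the scatter) that is small and of uncertain direction. Compound 4 is therefore expected to give 55%, within 25% to 80%.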

Compound 4, a percentage reported as activity, at one concentration (the size of the read-out at that concentration, not a potency): 36.3%
Compound 4: middle estimate off by 18.7 percentage points, on the high side; low and high end bracket the measured number.
By their numbers in this assay, from the lowest: compound 3; then compound 4; then compounds 2 and 1 (each within the scatter of the next).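

Among the compounds shown here, on the aromatic carbon para to a large group, compound 1 and compound 4 form the only pair that differs in one place, and in this assay methoxy in place of fluoro gives a number 30 percentage points lower from compound 1 to compound 4 (beyond the scatter). The read-out at this position therefore responds to this exchange on the core of compound 1. No available measurement offers an explanation for the step.

The compounds shown leave open how an amine or a hydroxyl group on this carbon would read. They also leave open whether plain hydrogen there would sit nearer compound 1 or compound 4.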